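Carboxypyridinyl thioether replacing naphthyl in benzothiazole amide series

A few compounds are considered here, and "the series" means these few. Any claim that something is new, unique, unknown or untested is made for them only; others in the source may bear on it.

Compound 2 `O=C(CSc1ccc2ccccc2c1)Nc1ccc2nc(NC(=O)c3ccc(C(F)(F)F)cc3)sc2c1` is measured in a functional assay on U2OS cells (Homo sapiens) for antiproliferative activity, read by MTT assay, with a stated time of 72 h (on this read-out higher numbers stand for weaker inhibition and lower numbers for stronger inhibition), at 3940 nM. Of the three numbers, compound 1 `O=C(CSc1ncccn1)Nc1ccc2nc(NC(=O)c3ccc(C(F)(F)F)cc3)sc2c1` gives 28100 nM and compound 3 `Cc1ccc(C(=O)Nc2nc3ccc(NC(=O)CSc4ccc(Cl)cc4)cc3s2)cc1` gives 3190 nM; the gap from compound 2 to compound 3 lies within the scatter, while the step of a 7.1-fold lower number from compound 1 to compound 2 (0.85 log units; beyond the scatter) is the only one beyond it. The step to compound 4 `O=C(CSc1ncccc1C(=O)O)Nc1ccc2nc(NC(=O)c3ccc(C(F)(F)F)cc3)sc2c1` changes the same position: 3-carboxypyridin-2-yl in place of naphthalen-2-yl on a sulfur. Within the data shown here, the one step that bears on this place, a 7.1-fold lower number from compound 1 to compound 2 (0.85 log units; beyond the scatter), went from a small six-membered heteroaryl on the sulfur to the two-ring carbon aryl and gave a modest drop in the number. Compound 4 reverses that direction, returning a single heteroaryl ring on the sulfur, now bearing a carboxylic acid for which no comparison exists in this assay. A rise in the number of roughly the size of that earlier step is therefore expected, a 5.1-fold higher number from compound 2 to compound 4 (0.71 log units; beyond the scatter), with wide uncertainty. The estimate for compound 4 in this assay is 20000 nM, expected between 6000 nM and 70000 nM.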

Compound 4, half-maximal inhibitory concentration: 13600 nM
The estimate for compound 4 lay 1.5-fold (0.17 log units) above the measured number; the measured number falls inside the stated range.
By their numbers in this assay, from the lowest: compounds 3 and 2 (each within the scatter of the next); then compound 4; then compound 1.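

In this assay, the position on the sulfur accepts a single heteroaryl ring bearing a carboxylic acid with only a modest penalty against the two-ring aryl: 3-carboxypyridin-2-yl in place of naphthalen-2-yl gives a 3.5-fold higher number from compound 2 to compound 4 (0.54 log units; beyond the scatter). The same group in place of pyrimidin-2-yl gives a 2.1-fold lower number from compound 1 to compound 4 (0.32 log units; beyond the scatter), so among the groups compared at this position on this core, the single heteroaryl rings do not behave alike, and naphthalen-2-yl remains the better of the three. No data available here explain this order.

Going by these compounds, the step from pyrimidin-2-yl changes both the ring and the substituent, so the share of the carboxylic acid in it remains open. An unsubstituted pyridin-2-yl, or a methyl ester or primary amide in place of the acid, would separate these contributions.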